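Propyl to tert-butyl on the aryl ring of compound 1

This account rests on a few compounds, and the source may have more. Where it says the series, first, only, none or still open, it means among the compounds named here.

In a functional assay on HT-29 cells (Homo sapiens) for antiproliferative activity, read by MTT assay, with a stated time of 96 h (on this read-out lower numbers stand for stronger inhibition and higher numbers for weaker inhibition), compound 1 `CCCc1ccc(N2C(=O)NC3(CSC4=C3C(=O)c3ncccc3C4=O)C2=O)cc1` gives 1 nM, the only number shown for it, with one further entry that is not a single number. The bare core, compound 2 `O=C1NC(=O)C2(CSC3=C2C(=O)c2ncccc2C3=O)N1`, gives 190 nM; 180 nM; 190 nM (3 entries) in this assay, repeated across several entries (the several entries of compound 2 in this assay, 190 nM; 180 nM; 190 nM (3 entries)). Compound 3 `CC(C)(C)c1ccc(N2C(=O)NC3(CSC4=C3C(=O)c3ncccc3C4=O)C2=O)cc1` differs from compound 1 by tert-butyl in place of propyl on an aromatic carbon. Among the compounds with values here, with no measured step of this kind at hand, the expected change in this assay a 1.5-fold higher number from compound 1 to compound 3 (0.18 log units; within the scatter) is small, if anything toward weaker inhibition, within the usual scatter. Compound 3 is therefore estimated at 1.5 nM, between 0.5 nM and 5 nM.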

Compound 3, half-maximal inhibitory concentration: 150 nM
Compound 3: the middle estimate sits 100-fold (2.00 log units) below what was measured, outside the stated range (above it).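

In this assay, the aromatic carbon para to a large group proves highly sensitive to the choice of alkyl group: tert-butyl in place of propyl gives a 150-fold higher number from compound 1 to compound 3 (2.18 log units; beyond the scatter). The low number of compound 1 therefore depends on the propyl group and not on the mere presence of a substituted aryl ring. With tert-butyl, compound 3 at 150 nM reads much like the bare core, compound 2: the several entries of compound 2 in this assay, 190 nM; 180 nM; 190 nM (3 entries)

Open, on these data alone, is how the number behaves between these two groups. Isopropyl or a longer chain such as butyl at this carbon would show whether branching or chain length governs the step.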